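This account rests on a few compounds, and the source may have more. Where it says the series, first, only, none or still open, it means among the compounds named here.

Measured in a functional assay on MCF7 cells (Homo sapiens) for inhibition, read by MTT assay, with a stated time of 48 h; a lower number here means a stronger inhibitor, a higher number a weaker inhibitor:
- compound 1 `COc1ccc(C(=O)C=CNc2cc(-c3ccccc3)nn2-c2ccccc2)cc1`: 1290 nM
- compound 2 `c1ccc(-c2ccnc3c2c(-c2ccccc2)nn3-c2ccccc2)cc1`: 28200 nM
- compound 3 `O=C(C=CNc1cc(-c2ccccc2)nn1-c1ccccc1)c1cccs1`: 15400 nM

The value of compound 2 lies within the scatter of that of compound 3, so these two cannot be told apart. Both are well beyond the scatter from compound 1, which has the lowest number and is the strongest inhibitor of the three.

Compound 4 `Fc1ccc(-c2ccnc3c2c(-c2ccccc2)nn3-c2ccccc2)cc1` keeps the core of compound 2 and changes one spot: fluoro in place of hydrogen on an aromatic carbon. A phenyl thus becomes 4-fluorophenyl.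

For the measured compounds named here, only one measured step is available, a 12-fold higher number from compound 1 to compound 3 (1.08 log units; beyond the scatter). It bears weakly here, since it swaps one whole group for another on a carbonyl carbon and belongs to the core of compound 1, not that of compound 2. Going by the values given here, no measured step shows what fluoro does in this assay, so no clear shift in either direction is expected.

The estimated step is a 1.1-fold lower number from compound 2 to compound 4 (0.05 log units; within the scatter), which is expected to stay within the scatter. For compound 4 the expected value is 25000 nM, with an estimated range of 9000 nM to 70000 nM.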

Compound 4, half-maximal inhibitory concentration: 1570 nM
Compound 4: the middle estimate sits 16-fold (1.20 log units) above what was measured, and the stated range ends above it.
By their numbers in this assay, from the lowest: compounds 1 and 4 (each within the scatter of the next); then compounds 3 and 2 (each within the scatter of the next).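

Swapping one hydrogen for fluoro, which turns a phenyl into 4-fluorophenyl, gives an 18-fold lower number from compound 2 to compound 4 (1.25 log units; beyond the scatter) in this assay. This shows that the number in this assay can respond strongly to a single added atom at this position, para to a large group, whereas the earlier step swapped one whole group for another on a carbonyl carbon in a different core. No measurement at hand explains why this small change has so large an effect on the number.

Going by these compounds, it remains open whether this step is particular to fluoro, or whether chloro or an amine at the same place would give a similar shift. It is also unknown whether fluoro would have a similar effect on the other phenyl groups of this core or on those in the core of compound 1.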